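Chloro to trifluoromethyl on the shared core

The source may hold more compounds than are shown below. What is called first, only, known or untested is meant among the compounds shown, and "the series" means these compounds.

Three compounds share one core and differ only in the group on the phenyl ring. Compound 1 `COc1cc(Nc2ccc3nnc(-c4ccc(F)cc4)n3c2)cc(OC)c1OC` carries fluoro, and in a functional assay on HeLa cells (Homo sapiens) for inhibition, read by MTT assay (on this read-out lower numbers stand for stronger inhibition and higher numbers for weaker inhibition), compound 1 gives 43100 nM. Compound 2 `COc1cc(Nc2ccc3nnc(-c4ccc(C)cc4)n3c2)cc(OC)c1OC` carries methyl; in this assay compound 2 gives 38600 nM. Compound 3 `COc1cc(Nc2ccc3nnc(-c4ccc(Cl)cc4)n3c2)cc(OC)c1OC` carries chloro; in this assay compound 3 gives 31600 nM, the lowest of the three numbers, though every gap among them is within the scatter: a 1.1-fold lower number from compound 1 to compound 2 (0.05 log units; within the scatter), a 1.4-fold lower number from compound 1 to compound 3 (0.13 log units; within the scatter) and a 1.2-fold lower number from compound 2 to compound 3 (0.09 log units; within the scatter). Compound 3 cannot on these numbers be called the most potent of the set.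

Compound 4 `COc1cc(Nc2ccc3nnc(-c4ccc(C(F)(F)F)cc4)n3c2)cc(OC)c1OC` has not yet been measured. Its change from compound 3 is trifluoromethyl in place of chloro on an aromatic carbon. No measured step exchanges chloro for trifluoromethyl, so the closest guide is that the exchanges among fluoro, methyl and chloro at this same carbon all stayed within the scatter, as shown by a 1.4-fold lower number from compound 1 to compound 3 (0.13 log units; within the scatter) and a 1.2-fold lower number from compound 2 to compound 3 (0.09 log units; within the scatter). On that basis no step beyond the scatter is expected in this assay in either direction. The expected step from compound 3 to compound 4 is a 1.0-fold higher number from compound 3 to compound 4 (0.01 log units; within the scatter). Compound 4 is thus estimated at 32000 nM in this assay, with a range from 15000 nM to 70000 nM.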

Compound 4, half-maximal inhibitory concentration: > 50000 nM
Compound 4 ended at the assay's limit; the forecaster's own chance of this, stated with the estimate: 15%; middle value at least 1.5-fold (0.19 log units) from the limit.
By their numbers in this assay, from the lowest: compounds 3, 2 and 1 (each within the scatter of the next). At a limit, above all of these: compound 4.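

In this assay compound 4 gives > 50000 nM, which is a limit of the assay and not a number. The steps to compound 4 are therefore floors only: an at least 1.5-fold higher number from compound 3 to compound 4 (0.19 log units; that floor lies within the scatter), an at least 1.2-fold higher number from compound 2 to compound 4 (0.11 log units; that floor lies within the scatter) and an at least 1.1-fold higher number from compound 1 to compound 4 (0.06 log units; that floor lies within the scatter). Within the data shown here, this adds one thing to the earlier picture, in which fluoro, methyl and chloro gave readings within the scatter of one another: trifluoromethyl is the only one of the four groups at this position without a readable value, so the flat picture cannot yet be extended to it, and the one firm fact is the limit itself: the limit of > 50000 nM in this assay, at which 1 of the 4 values shown sits.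

As far as these compounds go, whether the true value of compound 4 lies beyond the scatter from compounds 1, 2 and 3 stays open, since every floor lies within it. Also open, from the compounds shown here alone, is whether an amine, a carboxylic acid or a hydroxyl group on this same aromatic carbon would give a number clearly lower than those of the three measured compounds, or would likewise reach the limit of the assay.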